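Swapping sulfamoyl for trifluoromethyl on an aziridine urea

A few compounds are considered here, and "the series" means these few. Any claim that something is new, unique, unknown or untested is made for them only; others in the source may bear on it.

Measured so far:
Compound 1, `N#CC1CN1C(=O)Nc1ccc(S(N)(=O)=O)cc1`, gives > 38000 nM in a functional assay on L1210 cells (Mus musculus) for inhibition, read by MTT assay; on this read-out higher numbers stand for weaker inhibition and lower numbers for stronger inhibition.
Compound 2, `CC(=O)c1cccc(NC(=O)N2CC2C#N)c1`, gives 9600 nM in this assay.

Compound 1 stands at a limit of this assay: the value > 38000 nM is not a number but the point beyond which no inhibition was detected, and the limit of > 38000 nM in this assay, at which 1 of the 2 values shown sits, shows that compound 1 is the one of the two measured compounds sitting there. Among the compounds with values here, compound 2 is the only compound with a real number, and its value is far from that limit; compounds 1 and 2 differ in more than one place, so their values are simply two points with no single step between them.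

Compound 3, `N#CC1CN1C(=O)Nc1ccc(C(F)(F)F)cc1`, has not been measured. It differs from compound 1 in one place: trifluoromethyl in place of sulfamoyl on an aromatic carbon. Within the data shown here, no measured step of this kind exists here, so the expectation rests on the change alone. A step toward stronger inhibition, beyond the scatter, is expected, of the size an at least 2.5-fold lower number from compound 1 to compound 3 (0.40 log units; beyond the scatter). For compound 3 the estimate in this assay is 15000 nM, with a range from 3000 nM to 80000 nM.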

Compound 3, half-maximal inhibitory concentration: 7800 nM
Beside the measured number, compound 3's estimate is 1.9-fold (0.28 log units) above it; low and high end bracket the measured number.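

Within the data shown here, this is the first single change that can be read in this assay: on an aromatic carbon para to a group of 8 heavy atoms, replacing sulfamoyl with trifluoromethyl gives an at least 4.8-fold lower number from compound 1 to compound 3 (0.68 log units; beyond the scatter). The position is therefore sensitive to the group it carries, even though both groups have 4 heavy atoms, but sulfamoyl has 1 hydrogen-bond donor and 2 hydrogen-bond acceptors while trifluoromethyl has 0 of each, and this one swap cannot show which difference matters. Compound 1 stands at a limit and not at a number, so the full size of the step remains unknown: the limit of > 38000 nM in this assay, at which 1 of the 3 values shown sits.

The compounds shown do not reveal whether trifluoromethyl itself is needed at this carbon or whether removing sulfamoyl is enough, a question that a plain hydrogen, a methyl or a chlorine in the same place could help to settle. They also leave open how an amine or a carboxylic acid on this carbon would behave, and whether the step would look the same with the nitrile on the core replaced by another group.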